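A dichlorophenyl urea on the dimethoxyquinoline scaffold

The compounds below may be only part of what the source reports. "The series", "measured", "known", "first", "only" and "open" are said of these compounds alone.

Three ureas built on a shared core have been examined in a functional assay on OVCAR-4 cells (Homo sapiens) for inhibition, read by sulforhodamine B assay, with a stated time of 48 h, tested at 10 uM; a lower number here means a stronger effect, a higher number a weaker effect of the compound at the concentration tested. Compound 1 `COc1cc2cc(Oc3ccc(NC(=O)Nc4ccccc4)cc3)c(C)nc2cc1OC` carries an unsubstituted phenyl on the urea and gives 70.2%. Compound 2 `COc1cc2cc(Oc3ccc(NC(=O)Nc4ccc(C(F)(F)F)cc4)cc3)c(C)nc2cc1OC` gives 49%, and compound 3 `COc1cc2cc(Oc3ccc(NC(=O)Nc4ccc(Cl)c(C(F)(F)F)c4)cc3)c(C)nc2cc1OC` gives 17.1%. Compound 3 thus stands lowest of the three: the step of a number 53.1 percentage points lower from compound 1 to compound 3 (beyond the scatter) is the largest seen, and a number 31.9 percentage points lower from compound 2 to compound 3 (beyond the scatter) is also well beyond the scatter, while a number 21.2 percentage points lower from compound 1 to compound 2 (beyond the scatter) is the smaller change.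

Compound 4 `COc1cc2cc(Oc3ccc(NC(=O)Nc4ccc(Cl)c(Cl)c4)cc3)c(C)nc2cc1OC` keeps the 4-chloro substituent of compound 3 and differs from it in a single place: chloro in place of trifluoromethyl on an aromatic carbon. The aryl group therefore goes from 4-chloro-3-(trifluoromethyl)phenyl to 3,4-dichlorophenyl. Within the data shown here, no measured step swaps chloro for trifluoromethyl directly. Among the measured compounds shown here, the steps that bear on it show that adding a halogenated group to the phenyl lowers the number each time, from the modest step of a number 21.2 percentage points lower from compound 1 to compound 2 (beyond the scatter) to the large step of a number 31.9 percentage points lower from compound 2 to compound 3 (beyond the scatter), so a halogen in this position appears to matter, but whether chloro matches trifluoromethyl cannot be read from the data.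

Compound 4 is therefore expected to remain close to compound 3, with a step of a number 6.9 percentage points higher from compound 3 to compound 4 (within the scatter) that may not exceed the scatter, giving an estimate of 24% within a range of 10% to 45%.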

Compound 4, a percentage reported as activity, at one concentration (the size of the read-out at that concentration, not a potency): 31.9%
Estimate against measurement, compound 4: 7.9 percentage points below; measured number inside the range.
By their numbers in this assay, from the lowest: compound 3; then compound 4; then compound 2; then compound 1.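

In this assay, among these compounds, the step of a number 14.8 percentage points higher from compound 3 to compound 4 (beyond the scatter) shows for the first time that the group on this aromatic carbon, ortho to a chloro group, still counts when the 4-chloro substituent stays in place: chloro and trifluoromethyl are not interchangeable here, and the trifluoromethyl of compound 3 gives the stronger effect. Among the compounds shown here, the 3,4-dichlorophenyl group nonetheless retains a clear advantage over the unsubstituted phenyl, with a number 38.3 percentage points lower from compound 1 to compound 4 (beyond the scatter), and it also improves on the single trifluoromethyl group, with a number 17.1 percentage points lower from compound 2 to compound 4 (beyond the scatter), so the second halogen-bearing substituent helps in both forms tested, though to different degrees. No measured property of either group is available to account for the difference between chloro and trifluoromethyl at this place.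

The compounds shown leave open how a bromo, a methoxy, a nitrile or an amine on this aromatic carbon would compare with chloro and trifluoromethyl. They also leave open whether the same order would hold across a full range of concentrations rather than at the single concentration read here.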